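Notes on the imide change from compound 3 to compound 4

The compounds below may be only part of what the source reports. "The series", "measured", "known", "first", "only" and "open" are said of these compounds alone.

Measured so far:
compound 1 `Cc1cc(Cl)cc(-c2ccnc3cc(CN4C(=O)C5CC5C4=O)sc23)c1C[C@H]1OCCN[C@@H]1C` gives 1.5 nM
compound 2 `Cc1cc(Cl)cc(-c2ccnc3cc(CN4C(=O)C5CC5C4=O)sc23)c1C[C@@H]1CNCCO1` gives 0.16 nM
compound 3 `Cc1cc(Cl)cc(-c2ccnc3cc(CN4C(=O)C5C(C4=O)C5(C)C)sc23)c1O[C@@H]1CCNC[C@@H]1C` gives 0.18 nM

All three were read in an assay on isolated protein for inhibition of ubiquitin carboxyl-terminal hydrolase 7 (Homo sapiens), read by fluorescence, with stated times of 30 min and 1 h; on this read-out higher numbers stand for weaker inhibition and lower numbers for stronger inhibition. Compound 3 stands second highest of the three numbers: compound 2 lies within the scatter of it, while compound 1 sits higher, beyond the scatter. Compound 4 `Cc1cc(Cl)cc(-c2ccnc3cc(CN4C(=O)C5CC5C4=O)sc23)c1O[C@@H]1CCNC[C@@H]1C` differs from compound 3 by a group of 8 heavy atoms (5 carbon, 1 nitrogen, 2 oxygen; one three-membered non-aromatic ring of carbon only, one five-membered non-aromatic ring with 1 hetero atom) in place of a group of 10 heavy atoms (7 carbon, 1 nitrogen, 2 oxygen; one three-membered non-aromatic ring of carbon only, one five-membered non-aromatic ring with 1 hetero atom), on a saturated chain carbon bound to an aromatic carbon. Going by the values given here, no measured step touches this change; the only step on record, a 9.4-fold lower number from compound 1 to compound 2 (0.97 log units; beyond the scatter), bears on a different part of the structure. Compounds 1 and 2 already carry the smaller imide group found in compound 4, and compound 2 sits within the scatter of compound 3. The step of a 1.1-fold higher number from compound 3 to compound 4 (0.05 log units; within the scatter) is therefore expected to stay within the scatter. Compound 4 is estimated at 0.2 nM, range 0.07 nM to 0.6 nM.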

Compound 4, half-maximal inhibitory concentration: 1.1 nM
Compound 4: middle estimate off by 5.5-fold (0.74 log units), on the low side, and the stated range ends below it.
By their numbers in this assay, from the lowest: compounds 2 and 3 (each within the scatter of the next); then compounds 4 and 1 (each within the scatter of the next).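

In this assay the imide group on the saturated chain carbon bound to an aromatic carbon clearly counts: the group of 8 heavy atoms in place of the larger imide group gives a 6.1-fold higher number from compound 3 to compound 4 (0.79 log units; beyond the scatter) with the rest of the structure unchanged. With the smaller imide group shared, (3-methylpiperidin-4-yl)oxy in place of (morpholin-2-yl)methyl gives a 6.9-fold higher number from compound 2 to compound 4 (0.84 log units; beyond the scatter) while in place of (3-methylmorpholin-2-yl)methyl it gives a 1.4-fold lower number from compound 1 to compound 4 (0.13 log units; within the scatter) and so compound 2 alone was a poor guide to this pairing. Nothing at hand explains these steps. On these data alone, whether ethyl or fluorine on the three-membered ring would match the larger imide group stays open.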